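Chain-end amine variation on the tetrahydroquinoline series

The source may report more compounds than this note shows. Statements on the series, on what has been measured and on what is new or still open speak of the compounds shown alone.

Measured so far:
compound 1 `c1cnc2c(c1)CCC[C@@H]2N(CCCN1CCNCC1)Cc1nc2ccccc2s1` gives 1200 nM in a functional assay on CCRF-CEM cells for antagonist activity at C-X-C chemokine receptor type 4 (Homo sapiens), read by calcium flux, with stated times of 25 min and 90 s; on this read-out lower numbers stand for stronger inhibition and higher numbers for weaker inhibition
compound 2 `CCN1CCN(CCCN(C[C@H]2Cc3ccccc3CN2)[C@H]2CCCc3cccnc32)CC1` gives 33 nM
compound 3 `c1ccc2c(c1)CN[C@@H](CN(CCC1CCNCC1)[C@H]1CCCc3cccnc31)C2` gives 150 nM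

Compound 3 holds the second highest number of the three. Its nearest neighbour is compound 2, which sits lower, and the gap is beyond the scatter; compound 1 sits furthest away, at a higher number, also beyond the scatter.

Compound 4 `c1ccc2c(c1)CN[C@@H](CN(CCCN1CCNCC1)[C@H]1CCCc3cccnc31)C2` is the next step from compound 3. The change is (piperazin-1-yl)methyl in place of piperidin-4-yl on a saturated chain carbon, two bonds along the chain from an amine nitrogen. It brings the chain end back toward the form found in compound 2, which carries the same ring with an extra ethyl on its second nitrogen.

Among the compounds with values here, the one measured step that bears on this is a 4.5-fold higher number from compound 2 to compound 3 (0.66 log units; beyond the scatter), where the chain end was changed in the same place and the number rose. Compound 4 undoes most of that change, keeping only the loss of the ethyl. The number for compound 4 is therefore expected to fall, with a step of about a 2.5-fold lower number from compound 3 to compound 4 (0.40 log units; beyond the scatter), landing between the values of compound 2 and compound 3. The estimate for compound 4 is 60 nM, within a range of 20 nM to 180 nM.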

Compound 4, half-maximal inhibitory concentration: 17 nM
Compound 4: middle estimate off by 3.5-fold (0.55 log units), on the high side, outside the stated range (below it).
By their numbers in this assay, from the lowest: compounds 4 and 2 (each within the scatter of the next); then compound 3; then compound 1.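

In this assay, this position responds more strongly than the earlier compounds showed: (piperazin-1-yl)methyl in place of piperidin-4-yl on a saturated chain carbon, two bonds along the chain from an amine nitrogen, gives an 8.8-fold lower number from compound 3 to compound 4 (0.95 log units; beyond the scatter) and accounts for the whole of the earlier 4.5-fold higher number from compound 2 to compound 3 (0.66 log units; beyond the scatter) between these chain ends. Hydrogen in place of ethyl on an amine nitrogen in a ring gives a 1.9-fold lower number from compound 2 to compound 4 (0.29 log units; within the scatter), so this series shows no measurable need for the ethyl on the piperazine. With the 3-(piperazin-1-yl)propyl end held fixed, 1,2,3,4-tetrahydroisoquinolin-3-yl in place of 1,3-benzothiazol-2-yl gives a 71-fold lower number from compound 1 to compound 4 (1.85 log units; beyond the scatter), the largest step in the set, which places that group among the main determinants of the read-out here.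

The compounds shown leave open what a morpholine ring or a longer chain at the chain end would give, and whether a methyl or an acetyl on the piperazine nitrogen would read like the ethyl and the hydrogen. Nothing at hand explains why any of these steps has the size it has.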